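Swapping Benzyloxy for Piperidinylmethyl on the Amide Carbonyl

The source may hold more compounds than are shown below. What is called first, only, known or untested is meant among the compounds shown, and "the series" means these compounds.

Among the measured compounds shown here, compound 3 `CN1Cc2c(NC(=O)OCc3ccccc3)cccc2C(c2ccccc2)C1` is one of three compounds measured in a functional assay on the whole organism for inhibition of sodium-dependent dopamine transporter (Mus musculus); a higher number here means that more compound is needed for the effect, a lower number that less compound is needed. In this assay compound 3 gives 25 mg/kg. Compound 2 `CCOC(=O)Nc1cccc2c1CN(C)CC2c1ccc(Cl)cc1` gives 21 mg/kg, a number that lies within the scatter of compound 3. Compound 1 `CN1Cc2c(N)cccc2C(c2ccc(Cl)cc2)C1` gives 1.5 mg/kg, which lies beyond the scatter from compound 3. For the measured compounds named here, the one measured step between compounds that differ in a single place is a 14-fold higher number from compound 1 to compound 2 (1.15 log units; beyond the scatter).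

Compound 4 `CN1Cc2c(NC(=O)CN3CCCCC3)cccc2C(c2ccccc2)C1` has not yet been measured. It differs from compound 3 by (piperidin-1-yl)methyl in place of benzyloxy on a carbonyl carbon. Going by the values given here, no measured step exchanges one group on that carbonyl carbon for another. Among the compounds with values here, the single measured step, from compound 1 to compound 2, concerns attaching a carbonyl-bearing group to the aromatic nitrogen, a feature that compound 3 and compound 4 share, so it bears on the present change only indirectly: compound 2 and compound 3, which both carry such a group, give numbers within the scatter of each other. The author therefore expects for compound 4 a step of a 1.3-fold lower number from compound 3 to compound 4 (0.10 log units; within the scatter), with no firm ground for movement beyond the scatter in either direction. Compound 4 is estimated at 20 mg/kg, within a range from 7 mg/kg to 60 mg/kg.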

Compound 4, dose for half-maximal effect: about 60 mg/kg
Estimate against measurement, compound 4: 3.0-fold (0.48 log units) below, and the stated range covers the measured number.
By their numbers in this assay, from the lowest: compound 1; then compounds 2 and 3 (each within the scatter of the next); then compound 4.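

Among the compounds shown here, the new step is the first measured exchange on the carbonyl carbon itself: in this assay, (piperidin-1-yl)methyl in place of benzyloxy gives a 2.4-fold higher number from compound 3 to compound 4 (0.38 log units; beyond the scatter). This shows that the group held on this carbonyl carbon can move the number beyond the scatter, in the direction of more compound being needed, even though the amide-type nitrogen stays acylated in both compounds. Nothing at hand explains this move, so the data record its size and direction but not its origin.

A single exchange cannot separate its parts, as the aromatic carbon ring of benzyloxy gives way to a non-aromatic ring with a hetero atom while the oxygen on the carbonyl carbon gives way to a carbon, so the step may belong to either change or to both. Open too, going by these compounds, is how a morpholine, a dimethylamino group or a plain benzyl on the same carbonyl carbon would compare, and whether the exchange would give a like step on the core of compound 2, which carries a chlorine.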